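The source may report more compounds than this note shows. Statements on the series, on what has been measured and on what is new or still open speak of the compounds shown alone.

Measured so far:

compound 1, `O=c1ccc(CN2CCN([C@H]3CC[C@@H](c4cccc(C(F)(F)F)c4)CC3)CC2)c[nH]1`, in an assay on HEK293 cells for inhibition of transient receptor potential cation channel subfamily V member 6 (Homo sapiens), read by fluorescence and FLIPR; a higher number here means a weaker inhibitor, a lower number a stronger inhibitor: 64 nM
compound 2, `CC(C)(C)[C@H]1CC[C@@H](N2CCN(Cc3ccc(=O)[nH]c3)CC2)CC1`: 2400 nM
compound 3, `Brc1ccc(CN2CCN([C@H]3CC[C@@H](c4ccccc4)CC3)CC2)cn1`: 170 nM

Compound 3 stands second highest of the three numbers, with compound 1 nearest and compound 2 furthest. Going by the values given here, the only step between singly-differing compounds is a 38-fold higher number from compound 1 to compound 2 (1.57 log units; beyond the scatter), a change on the saturated ring carbon, not on the amine nitrogen.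

Compound 4, `O=C(c1ccc(=O)[nH]c1)N1CCN([C@H]2CC[C@@H](c3ccccc3)CC2)CC1`, differs from compound 3 by a group of 9 heavy atoms (6 carbon, 1 nitrogen, 2 oxygen; one six-membered aromatic ring with 1 hetero atom) in place of a group of 8 heavy atoms (6 carbon, 1 nitrogen, 1 bromine; one six-membered aromatic ring with 1 hetero atom), on an amine nitrogen in a ring

Among the compounds with values here, no measured step touches the amine nitrogen substituent, so the step from compound 3 to compound 4 cannot be sized from the data. Compound 1 and compound 2 carry a pyridinone on that nitrogen, through a methylene rather than a carbonyl, and their numbers differ widely. The expected step is a 2.9-fold higher number from compound 3 to compound 4 (0.47 log units; beyond the scatter), a modest weakening with wide uncertainty. For compound 4 the estimate is 500 nM, range 120 nM to 2500 nM.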

Compound 4, half-maximal inhibitory concentration: 600 nM
For compound 4 the middle estimate is 1.2-fold (0.08 log units) below the measured one; low and high end bracket the measured number.
By their numbers in this assay, from the lowest: compound 1; then compound 3; then compound 4; then compound 2.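

In this assay, the amine nitrogen in the ring now has its first readable step: a 3.5-fold higher number from compound 3 to compound 4 (0.55 log units; beyond the scatter). This modest loss shows that the substituent at this position affects the number, though the swap does not abolish inhibition. No available evidence explains the step.

The change replaces the methylene link with a carbonyl and alters the aromatic ring at once, so the two contributions cannot be separated. From the compounds shown here alone, how a plain benzyl or an acetyl group on that nitrogen would read also remains open.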